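Carbamate in place of benzoate ester on the oxazolidinone side chain

The source may hold more compounds than are shown below. What is called first, only, known or untested is meant among the compounds shown, and "the series" means these compounds.

Measured compounds:
compound 1 `O=C1O[C@@H](CO)CN1c1ccc(-n2cc(-c3ccccn3)cn2)c(F)c1`, 59 ug/mL
compound 2 `CC(=O)OC[C@H]1CN(c2ccc(-n3cc(-c4ccccn4)cn3)c(F)c2)C(=O)O1`, > 400 ug/mL
compound 3 `O=C(OC[C@H]1CN(c2ccc(-n3cc(-c4ccccn4)cn3)c(F)c2)C(=O)O1)c1ccccc1`, > 400 ug/mL

In an ADME assay on L02 cells (Homo sapiens) for cytotoxicity, read by MTT assay, with a stated time of 48 h (on this read-out higher numbers stand for weaker inhibition and lower numbers for stronger inhibition), compound 1 gives 59 ug/mL. Compound 2 gives only a limit of the assay, > 400 ug/mL. Compound 3 likewise gives only a limit, > 400 ug/mL, so its place in this assay is known only as standing at the limit of > 400 ug/mL in this assay, at which 2 of the 3 values shown sit, alongside compound 2. The two steps that reach there, an at least 6.7-fold higher number from compound 1 to compound 2 (0.83 log units; beyond the scatter) and an at least 6.7-fold higher number from compound 1 to compound 3 (0.83 log units; beyond the scatter), are both beyond the scatter, and the step that the two limits leave unreadable from compound 2 to compound 3 cannot be sized.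

Compound 4 `COC(=O)NC[C@H]1CN(c2ccc(-n3cc(-c4ccccn4)cn3)c(F)c2)C(=O)O1` differs from compound 3 by (methoxycarbonyl)amino in place of benzoyloxy on a saturated chain carbon bound to a saturated ring carbon. Within the data shown here, no measured step swaps an ester for a carbamate here; the only related evidence is that capping the hydroxyl of compound 1 as either ester moved the number up to the limit. Compound 4 is therefore expected to stay at the weak end of this assay, which means an estimated step of an at least 1.6-fold lower number from compound 3 to compound 4 (0.20 log units; that floor lies within the scatter). The value for compound 4 is estimated at 250 ug/mL, with a range from 80 ug/mL to 400 ug/mL.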

Compound 4, half-maximal inhibitory concentration: 71 ug/mL
Beside the measured number, compound 4's estimate is 3.5-fold (0.55 log units) above it, and the stated range ends above it.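

In this assay, among these compounds, the earlier compounds showed only that the two esters on a saturated chain carbon bound to a saturated ring carbon stood at the limit, and compound 4 shows that not every capped group at this place does: (methoxycarbonyl)amino in place of benzoyloxy gives an at least 5.6-fold lower number from compound 3 to compound 4 (0.75 log units; beyond the scatter), and in place of acetoxy it gives an at least 5.6-fold lower number from compound 2 to compound 4 (0.75 log units; beyond the scatter). Both steps start from compound values that are limits of the assay, not numbers: the limit of > 400 ug/mL in this assay, at which 2 of the 4 values shown sit. Against the free hydroxy group, (methoxycarbonyl)amino gives a 1.2-fold higher number from compound 1 to compound 4 (0.08 log units; within the scatter), so the two cannot be told apart here.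

As far as these compounds go, what stays open is whether this result is particular to (methoxycarbonyl)amino or extends to other nitrogen-linked groups. A plain amine, an acetamide or a longer chain at this place would address that.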